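A few compounds are considered here, and "the series" means these few. Any claim that something is new, unique, unknown or untested is made for them only; others in the source may bear on it.

Measured compounds in an assay on CHO cells for inhibition of Glucagon receptor (Homo sapiens), tested at 20 uM; on this read-out higher numbers stand for more inhibition at the one concentration tested (going by the name of the read-out) and lower numbers for less inhibition:
- compound 1, `CCCCCc1c(C(C)C)nc(C(C)C)c(CO)c1-c1ccc(C(F)(F)F)cc1`: 35%
- compound 2, `CCCCCc1c(C(C)C)nc(C(C)C)c(CO)c1-c1ccc(C(C)C)cc1`: 34%
- compound 3, `CCCCCc1c(C(C)C)nc(C(C)C)c(CO)c1-c1ccc2c(c1)CCCC2`: 37%

Compound 2 stands alongside the other two: the values of compound 1 and compound 3 both lie within the usual scatter of the value of compound 2, so the three numbers cannot be told apart on this read-out. Within the data shown here, the one directly comparable step, a number 1 percentage points lower from compound 1 to compound 2 (within the scatter), is within the scatter; the pair compound 2 and compound 3 has no single-point step, and their two values likewise lie within the scatter of each other.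

The next compound is compound 4, `CCCCCc1c(C(C)C)nc(C(C)C)c(CO)c1-c1ccccc1OC`. Its difference from compound 2 is 2-methoxyphenyl in place of 4-isopropylphenyl on an aromatic carbon.

What bears on this step is the set of aryl-group exchanges already measured: trifluoromethyl to isopropyl on the aryl carbon gave a number 1 percentage points lower from compound 1 to compound 2 (within the scatter), and the ring-fused variant, compound 3, gave a value in the same range. Each exchange of the aryl group so far has left the read-out where it was. The move to 2-methoxyphenyl brings an oxygen acceptor and a different substitution pattern, so a somewhat larger spread is allowed than for the measured steps, but no step beyond the scatter is expected in either direction. The expected step is a number 4 percentage points lower from compound 2 to compound 4 (within the scatter), and the estimate for compound 4 is 30%, within 15% to 45%.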

Compound 4, a percentage reported as inhibition, at one concentration (the size of the read-out at that concentration, not a potency): 27%
For compound 4 the middle estimate is 3 percentage points above the measured one; the measured number falls inside the stated range.
By their numbers in this assay, from the lowest: compounds 4, 2, 1 and 3 (each within the scatter of the next).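

In this assay, among these compounds, the step of a number 7 percentage points lower from compound 2 to compound 4 (within the scatter) is the first measured exchange of the whole aryl group at the position opposite the ring nitrogen, and it stays within the scatter even though 4-isopropylphenyl leaves and 2-methoxyphenyl enters. This position therefore keeps its read-out not only across changes of the aryl substituent but also with a hydrogen-bond acceptor on the entering group and a different substitution pattern, and the four compounds now form a chain in which each value lies within the scatter of the next. No measurement shown here accounts for this flat response.

As far as these compounds go, it remains open whether any group at this position moves the read-out beyond the scatter, for instance a phenyl ring carrying a carboxylic acid or an amine. Also open, from the compounds shown here alone, is the contribution of the groups shared by all four compounds, which could be probed with a longer chain in place of pentyl or a carboxylic acid in place of hydroxymethyl, and a single tested concentration gives no potency for any of them.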